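Moving the chlorine to another place on the aryl ring

This account rests on a few compounds, and the source may have more. Where it says the series, first, only, none or still open, it means among the compounds named here.

In an assay on CHO cells for displacement of a labelled ligand from adenosine receptor A3 (Homo sapiens), read by scintillation counting, with a stated time of 3 h (on this read-out higher numbers stand for weaker inhibition and lower numbers for stronger inhibition), compound 2 `Cn1c(-c2ccc(O)cc2)nc2c(NC3CCCC3)ncnc21` gives 521 nM, and compound 1 `Cn1c(-c2cccc(Cl)c2)nc2c(NC3CCCC3)ncnc21` gives 514 nM, the two numbers lying within the scatter of each other. The change to compound 3 `Cn1c(-c2ccccc2Cl)nc2c(NC3CCCC3)ncnc21` is 2-chlorophenyl in place of 4-hydroxyphenyl on an aromatic carbon. Among the compounds with values here, the one measured step, a 1.0-fold higher number from compound 1 to compound 2 (0.01 log units; within the scatter), also swapped one aryl substituent for another and left the number essentially unchanged; it bears on the present change only loosely, since no measured pair contains a 2-chlorophenyl. No step beyond the scatter is therefore expected, a 1.2-fold higher number from compound 2 to compound 3 (0.06 log units; within the scatter). Compound 3 is estimated at 600 nM, between 200 nM and 1800 nM.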

Compound 3, inhibition constant: 720 nM
Estimate against measurement, compound 3: 1.2-fold (0.08 log units) below; the measured number falls inside the stated range.
By their numbers in this assay, from the lowest: compounds 1, 2 and 3 (each within the scatter of the next).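

In this assay, 2-chlorophenyl in place of 3-chlorophenyl gives a 1.4-fold higher number from compound 1 to compound 3 (0.15 log units; within the scatter), and 2-chlorophenyl in place of 4-hydroxyphenyl gives a 1.4-fold higher number from compound 2 to compound 3 (0.14 log units; within the scatter). On this aromatic carbon between two ring nitrogen atoms, then, the chlorine can occupy a different place on the aryl ring, and the hydroxyl can give way to chlorine, without a step beyond the scatter. No supporting data explain why these numbers stay so close. On these data alone, whether an amine, a carboxylic acid or a longer chain on this carbon would keep the number in this range remains open, as does the result for plain phenyl.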